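The compounds below may be only part of what the source reports. "The series", "measured", "known", "first", "only" and "open" are said of these compounds alone.

Working notes on the anilide series. Compound 2 `Cc1ccc(F)cc1NC(=O)CN1CCN(c2nnc(Cc3ccccc3)c3ccccc23)CC1` is the parent of the step under review; in a functional assay on A549 cells (Homo sapiens) for cytotoxicity, read by MTT assay, with a stated time of 72 h (on this read-out higher numbers stand for weaker inhibition and lower numbers for stronger inhibition), compound 2 gives "not active" (no number reported), so no single number places it against the other members. Its nearest neighbours with numbers share the core but carry a pyridylmethyl in place of the benzyl: compound 1 `Cc1cccc(Cl)c1NC(=O)CN1CCN(c2nnc(Cc3ccncc3)c3ccccc23)CC1` gives 7190 nM in this assay, and compound 3 `Cc1ccccc1NC(=O)CN1CCN(c2nnc(Cc3ccncc3)c3ccccc23)CC1` gives 43100 nM in this assay. Among the compounds with values here, the only step between measured compounds that differ in one place is a 6.0-fold higher number from compound 1 to compound 3 (0.78 log units; beyond the scatter), a change on the anilide ring.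

Compound 4 `O=C(CN1CCN(c2nnc(Cc3ccccc3)c3ccccc23)CC1)Nc1c(F)cccc1F` differs from compound 2 in the same region: 2,6-difluorophenyl in place of 5-fluoro-2-methylphenyl on an amide-type nitrogen. This is a change of the aromatic substitution pattern on the anilide, not a single swap, so the step from compound 1 to compound 3 bears on it only loosely; it shows that the anilide substituents move this assay by a modest amount. Within the data shown here, compound 2 offers no number from which to compute a step, and no measured pair covers a methyl-to-fluoro exchange, so no direction beyond the scatter can be claimed. On the weak activity of the benzyl-bearing compound 2 and the modest anilide effects seen, compound 4 is expected to remain weak in this assay, estimated around 40000 nM with a range from 10000 nM to 200000 nM, with a real chance that only a limit is reported.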

Compound 4, half-maximal inhibitory concentration: 84500 nM
Beside the measured number, compound 4's estimate is 2.1-fold (0.32 log units) below it; measured number inside the range.
By their numbers in this assay, from the lowest: compound 1; then compounds 3 and 4 (each within the scatter of the next).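

Within the data shown here, compound 2 has no number in this assay, and no step from it to compound 4 can be read. No measured evidence bears on this result. The compounds shown leave open how far 2,6-difluorophenyl in place of 5-fluoro-2-methylphenyl on the amide-type nitrogen moves this assay when the rest of the structure stays the same.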